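Removing a trifluoromethyl group from two related anilide cores

This account rests on a few compounds, and the source may have more. Where it says the series, first, only, none or still open, it means among the compounds named here.

The study concerns a small set of anilides sharing a phenol-bearing aryl unit joined to a benzamide, tested in a functional assay on DU-145 cells (Homo sapiens) for antiproliferative activity, read by fluorescence and propidium iodide staining, with a stated time of 96 h; on this read-out higher numbers stand for weaker inhibition and lower numbers for stronger inhibition. Compound 1 `O=C(Nc1cc(C(F)(F)F)cc(C(F)(F)F)c1)c1ccc(Sc2ccc(O)cc2)cc1` gives 5600 nM, and compound 2 `O=C(Nc1cccc(C(F)(F)F)c1)c1ccc(Sc2ccc(O)cc2)cc1` gives 5950 nM. The two differ by hydrogen in place of trifluoromethyl on an aromatic carbon, a change that produced a 1.1-fold higher number from compound 1 to compound 2 (0.03 log units; within the scatter). Compound 3 `O=C(Nc1cc(C(F)(F)F)ccc1C(F)(F)F)c1ccc(S(=O)(=O)c2ccc(O)cc2)cc1` carries a different core; in this assay compound 3 gives 27800 nM, the highest of the three numbers. How the core of compound 3 differs from that of compound 1 is not broken down here, so their values are only set side by side.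

Compound 4 `O=C(Nc1ccccc1C(F)(F)F)c1ccc(S(=O)(=O)c2ccc(O)cc2)cc1` is not yet measured. It differs from compound 3 by hydrogen in place of trifluoromethyl on an aromatic carbon. Within the data shown here, this is the same kind of change as the one from compound 1 to compound 2, though not the same: in compound 1 the departing trifluoromethyl sits meta to a trifluoromethyl group, whereas in compound 3 it sits para to a trifluoromethyl group. Since the earlier removal gave a 1.1-fold higher number from compound 1 to compound 2 (0.03 log units; within the scatter), a step within the scatter, the number for compound 4 is expected to move by about a 1.1-fold higher number from compound 3 to compound 4 (0.03 log units; within the scatter), resting on that single precedent and on the value of compound 3, 27800 nM. Compound 4 is therefore estimated at 30000 nM in this assay, between 12000 nM and 75000 nM.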

Compound 4, half-maximal inhibitory concentration: 45900 nM
Compound 4: the middle estimate sits 1.5-fold (0.18 log units) below what was measured; the range from low to high includes it.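

In this assay, putting hydrogen in place of trifluoromethyl on an aromatic carbon gave a 1.7-fold higher number from compound 3 to compound 4 (0.22 log units; within the scatter), and this step agrees with the earlier one on the other core: the same change on two cores in this assay, a 1.1-fold higher number (0.03 log units; within the scatter) from compound 1 to compound 2 and a 1.7-fold higher number (0.22 log units; within the scatter) from compound 3 to compound 4, 1.6-fold (0.19 log units) apart, within the scatter of two such steps On the two cores shown, then, the change carries over in the limited sense that neither step leaves the scatter, so the result for one pair would have served as a fair guide to the other. It does not show that the change has a real effect on either core, since what agrees here is two small steps rather than a clear shift, and two pairs cannot establish that the same would hold on a further core or where the departing trifluoromethyl stands elsewhere on the ring than para to a trifluoromethyl group, as it does in compound 3.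

The compounds shown leave open what other groups on that aromatic carbon, such as an amine, a nitrile or a carboxylic acid, would do to the number on either core. They also leave open what would follow if the remaining trifluoromethyl group in compound 2 or compound 4 gave way to hydrogen or to a longer chain.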